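Methyl on the pyrazole and clearance in rat hepatocytes

A few compounds are considered here, and "the series" means these few. Any claim that something is new, unique, unknown or untested is made for them only; others in the source may bear on it.

Measured compounds:
Compound 1, `COCc1ccc(-c2ccc3nnc(C(N)=O)c(N[C@@H](C)c4ccn(C)n4)c3c2)cn1`, gives 4.9 uL/min in an ADME assay on cells (Hepatocyte, Rattus norvegicus) for metabolic stability, read by HPLC, with a stated time of 30 min, tested at 1 uM; on this read-out lower numbers stand for slow clearance and higher numbers for fast clearance.
Compound 2, `COCc1ccc(-c2ccc3nnc(C(N)=O)c(N[C@@H](C)c4nn(C)cc4C)c3c2)cn1`, gives 18 uL/min in this assay.
Compound 3, `C[C@H](Nc1c(C(N)=O)nnc2ccc(-c3ccc(OCCCN4CCCC4)nc3)cc12)c1ccn(C)n1`, gives 4.6 uL/min in this assay.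

The three compounds share one core, and two changes are made on it. The first change is methyl in place of hydrogen on an aromatic carbon, and it gave a 3.7-fold higher number from compound 1 to compound 2 (0.57 log units; beyond the scatter). The second change is 3-(pyrrolidin-1-yl)propoxy in place of methoxymethyl on an aromatic carbon, and it gave a 1.1-fold lower number from compound 1 to compound 3 (0.03 log units; within the scatter), so compound 1 and compound 3 behave alike in this assay.

Compound 4, `Cc1cn(C)nc1[C@H](C)Nc1c(C(N)=O)nnc2ccc(-c3ccc(OCCCN4CCCC4)nc3)cc12`, has not yet been measured in this assay. It is related to compound 3 by methyl in place of hydrogen on an aromatic carbon, and this is the same change that was made from compound 1 to compound 2. The surroundings of the change are described in the same words in both pairs, and the two starting compounds differ only by the change described under compound 3.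

On this basis compound 4 is expected to behave much as compound 2 did relative to compound 1: the step from compound 3 to compound 4 is estimated at a 3.5-fold higher number from compound 3 to compound 4 (0.54 log units; beyond the scatter), because compound 1 to compound 2 showed a 3.7-fold higher number from compound 1 to compound 2 (0.57 log units; beyond the scatter). For the measured compounds named here, the estimate for compound 4 in this assay is therefore 16 uL/min, with a plausible range from 7 uL/min to 35 uL/min, the width reflecting that only one earlier example of this change is available.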

Compound 4, intrinsic clearance in a liver preparation (reported as CLH), per the amount of preparation that the assay uses: 8.1 uL/min
For compound 4 the middle estimate is 2.0-fold (0.30 log units) above the measured one; low and high end bracket the measured number.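

Placed on the core that carries 3-(pyrrolidin-1-yl)propoxy, the added methyl gives a 1.8-fold higher number from compound 3 to compound 4 (0.25 log units; within the scatter) in this assay, so here the step cannot be told apart from repeat measurements, whereas on the core that carries methoxymethyl the same methyl gave a step beyond the scatter. Even so, the two methyl steps are no further apart than two such steps can be by chance, so the data do not show that the methyl acts differently on the two cores, nor do they prove that its effect carries over unchanged: the same change on two cores in this assay, a 3.7-fold higher number (0.57 log units; beyond the scatter) from compound 1 to compound 2 and a 1.8-fold higher number (0.25 log units; within the scatter) from compound 3 to compound 4, 2.1-fold (0.32 log units) apart, within the scatter of two such steps. The swap of methoxymethyl for 3-(pyrrolidin-1-yl)propoxy reads the same way, with a 2.2-fold lower number from compound 2 to compound 4 (0.35 log units; beyond the scatter) set against a step within the scatter in the other pair, and again two pairs are too few to separate a real dependence on the core from ordinary scatter: the same change on two cores in this assay, a 1.1-fold lower number (0.03 log units; within the scatter) from compound 1 to compound 3 and a 2.2-fold lower number (0.35 log units; beyond the scatter) from compound 2 to compound 4, 2.1-fold (0.32 log units) apart, within the scatter of two such steps.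

The compounds shown leave open what an ethyl group or a fluorine atom would do on the same aromatic carbon of the pyrazole. They also leave open whether a morpholine in place of the pyrrolidine, or a shorter chain joining the amine to the oxygen, would give the same picture in this assay.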